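A Methoxyphenyl Rearrangement on a Bromo-Substituted Core

The source may hold more compounds than are shown below. What is called first, only, known or untested is meant among the compounds shown, and "the series" means these compounds.

Four related compounds are considered here. Compound 1 `COc1cccc(C(=O)n2c(-c3cn(C)c4ccc(OC)cc34)nc3ccccc32)c1`, compound 2 `COc1ccc(C(=O)n2c(-c3cn(C)c4ccc(OC)cc34)nc3ccccc32)cc1` and compound 3 `COc1cccc(C(=O)n2c(-c3cn(C)c4ccc(Br)cc34)nc3ccccc32)c1` have been tested in a functional assay on HepG2 cells (Homo sapiens) for inhibition, read by MTT assay, with a stated time of 24 h (a higher number here means a weaker inhibitor of growth, a lower number a stronger inhibitor of growth), while compound 4 `COc1ccc(C(=O)n2c(-c3cn(C)c4ccc(Br)cc34)nc3ccccc32)cc1` has not.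

In this assay compound 1 gives 11700 nM, compound 2 gives 12800 nM, and compound 3 gives 17800 nM. Compound 1 and compound 2 differ by 4-methoxyphenyl in place of 3-methoxyphenyl on a carbonyl carbon, and this gave a 1.1-fold higher number from compound 1 to compound 2 (0.04 log units; within the scatter). Compound 1 and compound 3 differ in their cores by bromo in place of methoxy on an aromatic carbon, which gave a 1.5-fold higher number from compound 1 to compound 3 (0.18 log units; within the scatter). All three values lie within the usual scatter of one another, so no ranking among them can be drawn.

Compound 4 differs from compound 3 by 4-methoxyphenyl in place of 3-methoxyphenyl on a carbonyl carbon. Within the data shown here, this is the same change that separates compound 1 from compound 2, and the place is described in identical words in both cases, so the earlier step is the only guide. Because that step a 1.1-fold higher number from compound 1 to compound 2 (0.04 log units; within the scatter) stayed within the scatter, compound 4 is expected to show a step of a 1.1-fold higher number from compound 3 to compound 4 (0.04 log units; within the scatter) from compound 3, essentially no change. Compound 4 is therefore estimated at 19500 nM in this assay, with a plausible range from 9000 nM to 42000 nM.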

Compound 4, concentration for 50% growth inhibition: 18900 nM
The estimate for compound 4 lay 1.0-fold (0.01 log units) above the measured number; the range from low to high includes it.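

In this assay, putting 4-methoxyphenyl in place of 3-methoxyphenyl on the carbonyl carbon of the bromo-bearing core gave a 1.1-fold higher number from compound 3 to compound 4 (0.03 log units; within the scatter), and this change read the same on both cores: the same change on two cores in this assay, a 1.1-fold higher number (0.04 log units; within the scatter) from compound 1 to compound 2 and a 1.1-fold higher number (0.03 log units; within the scatter) from compound 3 to compound 4, 1.0-fold (0.01 log units) apart, within the scatter of two such steps. Bromo in place of methoxy on the aromatic carbon, now with 4-methoxyphenyl on the carbonyl carbon, gave a 1.5-fold higher number from compound 2 to compound 4 (0.17 log units; within the scatter), and this change also read the same on both cores: the same change on two cores in this assay, a 1.5-fold higher number (0.18 log units; within the scatter) from compound 1 to compound 3 and a 1.5-fold higher number (0.17 log units; within the scatter) from compound 2 to compound 4, 1.0-fold (0.01 log units) apart, within the scatter of two such steps. Together, these two pairs show that each change carries from one core to the other in this series as a step within the scatter, but they do not show that either change has any real effect on growth inhibition, nor that the same would hold on a core outside these four compounds.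

The compounds shown leave open how the series would read in this assay with an amine, a carboxylic acid or a longer alkoxy chain in place of the methoxy on the phenyl ring. They also leave open whether a change that produced a step beyond the scatter would carry from one core to the other as these two do.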